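The source may report more compounds than this note shows. Statements on the series, on what has been measured and on what is new or still open speak of the compounds shown alone.

Measured so far:
- compound 1, `O=C(NCCCCc1ccccc1)n1c(=O)oc2cc(C3CCOCC3)ccc21`: 68 nM
- compound 2, `CCC(C)NC(=O)n1c(=O)oc2cc(C3CCN(C)CC3)ccc21`: 2100 nM
- compound 3, `CCOCCNC(=O)n1c(=O)oc2cc(-c3ccc(F)cc3)ccc21`: 2300 nM

Of the compounds shown here, three sharing one core have been tested in an assay on HEK293 cells for inhibition of acid ceramidase (Homo sapiens), read by fluorescence, with stated times of 10 min and 3 h; on this read-out higher numbers stand for weaker inhibition and lower numbers for stronger inhibition. Compound 1 gives the lowest number of the three, 68 nM; compound 2 sits far higher at 2100 nM, and compound 3 higher still at 2300 nM. Both gaps lie beyond the scatter of repeated measurements. Since compound 2 and compound 3 differ from compound 1 in more than one place, the account draws no stepwise conclusion from them and treats compound 1 alone as the reference.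

The untested compound 4, `CC(C)CN1CCN(c2ccc3c(c2)oc(=O)n3C(=O)NCCCCc2ccccc2)CC1`, keeps the amide and the core of compound 1 and differs only in the group on the aromatic carbon: 4-isobutylpiperazin-1-yl in place of oxan-4-yl on an aromatic carbon

For the measured compounds named here, no measured pair isolates this exchange, so the expectation rests on compound 1 alone. The author expects the step in this assay from compound 1 to compound 4 to be small, a 1.8-fold higher number from compound 1 to compound 4 (0.25 log units; within the scatter), most likely toward a slightly higher number, and possibly none beyond the scatter. Compound 4 is therefore estimated at 120 nM, with a range from 30 nM to 500 nM.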

Compound 4, half-maximal inhibitory concentration: 127 nM
Estimate against measurement, compound 4: 1.1-fold (0.02 log units) below; low and high end bracket the measured number.
By their numbers in this assay, from the lowest: compounds 1 and 4 (each within the scatter of the next); then compounds 2 and 3 (each within the scatter of the next).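

In this assay, placing 4-isobutylpiperazin-1-yl instead of oxan-4-yl on this aromatic carbon gives a 1.9-fold higher number from compound 1 to compound 4 (0.27 log units; within the scatter), a step within the scatter. For the compounds shown here, this is the first exchange here that can be read on its own, and it shows that, with the amide and core of compound 1 kept, this place accepts the piperazine ring with its isobutyl chain without a change beyond the scatter. Nothing shown gives a reason for this outcome.

The compounds shown leave open how far this tolerance extends, for example to a piperazine with a hydrogen or a methyl in place of the isobutyl chain, or with a carboxylic acid at the end of that chain. They also leave open whether a morpholine ring at this place would fit the same picture.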